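The source may hold more compounds than are shown below. What is called first, only, known or untested is meant among the compounds shown, and "the series" means these compounds.

Measured so far in an ADME assay on a cell-free system (plasma, Homo sapiens); on this read-out lower numbers stand for a smaller free fraction and higher numbers for a larger free fraction:
- Compound 1 (`CCNC(=O)Nc1nc2cc(-c3ccc(F)nc3)c(=O)n(C)c2s1`): "not determined" (no result reported)
- Compound 2 (`CCNC(=O)Nc1nc2cc(-c3cccnc3)c(=O)n(C(C)C)c2s1`): 0.21
- Compound 3 (`CCNC(=O)Nc1nc2cc(-c3cncnc3)c(=O)n(C(C)C)c2s1`): 0.15

In this assay, for the measured compounds named here, compound 3 stands at 0.15 and compound 2 at 0.21 as the only two numbers, which lie within the scatter of each other. Compound 1 adds no number to compare.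

Compound 4 (`CCNC(=O)Nc1nc2cc(-c3cncc(F)c3)c(=O)n(C(C)C)c2s1`) carries 5-fluoropyridin-3-yl in place of pyrimidin-5-yl on an aromatic carbon, and the counted change is 5-fluoropyridin-3-yl in place of pyrimidin-5-yl on an aromatic carbon on the shared core.

Going by the values given here, one measured step bears on this. Pyrimidin-5-yl in place of pyridin-3-yl at the same carbon gave a 1.4-fold lower number from compound 2 to compound 3 (0.15 log units; within the scatter) in this read-out. Among the compounds with values here, compound 4 again has a ring with 1 hetero atom, but no measured step shows what the added fluorine does. No step beyond the scatter is therefore expected, and no firm direction. The estimated change is a 1.1-fold lower number from compound 3 to compound 4 (0.03 log units; within the scatter) and nothing larger is expected.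

In this assay the estimate for compound 4 is 0.14 with an expected range from 0.08 to 0.24 around it.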

Compound 4, unbound fraction in the plasma assay: 0.1
Estimate against measurement, compound 4: 1.4-fold (0.15 log units) above, within the range that was stated.
By their numbers in the plasma assay, from the lowest: compounds 4, 3 and 2 (each within the scatter of the next, the first and the last beyond it).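

For the compounds shown here, in the plasma assay, fluoro in place of hydrogen on an aromatic carbon of the pyridin-3-yl ring gave a 2.1-fold lower number from compound 2 to compound 4 (0.32 log units; beyond the scatter), the first step at this position to pass beyond the scatter, whereas the swap from pyrimidin-5-yl gave a 1.5-fold lower number from compound 3 to compound 4 (0.18 log units; within the scatter). This position therefore responds to the added fluorine in a way that the earlier pair, which differed only in ring nitrogens, did not show. The swap from pyrimidin-5-yl to 5-fluoropyridin-3-yl also registers clearly in a physicochemical assay for solubility, in phosphate buffer, at pH 7.4; on this read-out higher numbers stand for higher solubility and lower numbers for lower solubility: the measured solubility of compound 3, 7000 nM, and of compound 4, 73000 nM, a 10-fold higher number (1.02 log units; beyond the scatter). In the physicochemical assay, compound 3 gives 7000 nM and compound 4 gives 73000 nM.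

As far as these compounds go, it remains open whether a chlorine, a methoxy group or an amine in place of the fluorine would shift the number in the plasma assay further. Also open, from the compounds shown here alone, is how a longer chain in place of the isopropyl group would bear on either read-out.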